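This account rests on a few compounds, and the source may have more. Where it says the series, first, only, none or still open, it means among the compounds named here.

Compound 1 `CCNCc1ccc(Cl)c(-c2ccccc2OC)c1` shares its core with compound 2 `CCN(CC)Cc1ccc(Cl)c(-c2ccccc2OC)c1` and compound 3 `CCCCNCc1ccc(Cl)c(-c2ccccc2OC)c1`, the three differing only in the substituents on the amine nitrogen of the saturated chain. In an assay on isolated protein for binding affinity to 5-hydroxytryptamine receptor 1E (Homo sapiens) (on this read-out higher numbers stand for weaker inhibition and lower numbers for stronger inhibition), compound 1 gives > 10000 nM, which is a limit of the assay and not a number. Compound 2 likewise reaches only the limit > 10000 nM in this assay. Compound 3 also stops at the limit > 10000 nM in this assay. For the measured compounds named here, since (the limit of > 10000 nM in this assay, at which 3 of the 3 values shown sit), no step among them can be sized: the step that the two limits leave unreadable from compound 1 to compound 2, the step that the two limits leave unreadable from compound 1 to compound 3 and the step that the two limits leave unreadable from compound 2 to compound 3 all remain unreadable. Compound 4 `CNCc1ccc(Cl)c(-c2ccccc2OC)c1` has not yet been measured in this assay. It differs from compound 1 by hydrogen in place of methyl on a saturated chain carbon bound to an amine nitrogen. The steps from compound 1 to compound 2 and from compound 1 to compound 3 alter the same amine and therefore bear on this change, but the limit hides their size, so no direction can be read from them. With all three measured compounds at the limit, the expected step that the limit leaves unreadable from compound 1 to compound 4 is taken as none beyond the scatter. Compound 4 is accordingly estimated at 20000 nM in this assay, within a range from 5000 nM to 100000 nM, and most likely only a limit will again be reported.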

Compound 4, inhibition constant: 2400 nM
Beside the measured number, compound 4's estimate is 8.3-fold (0.92 log units) above it, outside the stated range (below it).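

Methylamino is the first group at this place to bring a compound off the limit: in this assay the change from ethylamino to methylamino gives an at least 4.1-fold lower number from compound 1 to compound 4 (0.61 log units; beyond the scatter) and so shows that this amine substituent can decide whether a number is read at all. The comparison with the other two amines points the same way, with an at least 4.1-fold lower number from compound 3 to compound 4 (0.61 log units; beyond the scatter) against the butylamino compound and an at least 4.1-fold lower number from compound 2 to compound 4 (0.61 log units; beyond the scatter) against the diethylamino compound. All three steps are bounds and not sizes, so the true difference may be larger, and the reading rests on compound 4 alone: the limit of > 10000 nM in this assay, at which 3 of the 4 values shown sit.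

Going by these compounds, the steps among compound 1, compound 2 and compound 3 cannot be read, so whether ethylamino, butylamino and diethylamino differ from one another in this assay stays unknown. Also open, on these data alone, is how a primary amine, a dimethylamino group or a cyclic amine such as pyrrolidine would stand at this place, and whether the same step would appear with another group in place of the chlorine or the methoxy on the shared core.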